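The source may hold more compounds than are shown below. What is called first, only, known or untested is meant among the compounds shown, and "the series" means these compounds.

In an ADME assay on microsomes from liver (Homo sapiens) for metabolic stability, read by LC-MS, tested at 1 uM (a lower number here means slower removal, a higher number faster removal of the compound), three compounds with the same core have been measured, and they differ only in the group on an amine nitrogen. Compound 1 `c1cc([C@H]2CC[C@]3(CC2)OOC2(O3)C3CC4CC(C3)CC2C4)ccc1OCCCNC1CCOCC1` gives 10 mL.min-1.g-1, and compound 3 `CC(C)(O)CNCCCOc1ccc([C@H]2CC[C@]3(CC2)OOC2(O3)C3CC4CC(C3)CC2C4)cc1` gives 8 mL.min-1.g-1, so these two numbers sit within the scatter of each other. Compound 2 `NCCCOc1ccc([C@H]2CC[C@]3(CC2)OOC2(O3)C3CC4CC(C3)CC2C4)cc1` gives only a limit, < 7 mL.min-1.g-1.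

Compound 4 `OC1(COc2ccc([C@H]3CC[C@]4(CC3)OOC3(O4)C4CC5CC(C4)CC3C5)cc2)CCNCC1` changes more than that nitrogen group: 4-hydroxypiperidin-4-yl in place of 2-((2-hydroxy-2-methylpropyl)amino)ethyl on a saturated chain carbon bound to an oxygen on an aromatic ring. Put simply, 4-hydroxypiperidin-4-yl stands in place of 2-((2-hydroxy-2-methylpropyl)amino)ethyl on a saturated chain carbon bound to an oxygen on an aromatic ring.

For the measured compounds named here, no measured step makes this same change, so the nitrogen swaps offer only indirect guidance. Going by the values given here, the one step between two real numbers is a 1.3-fold lower number from compound 1 to compound 3 (0.10 log units; within the scatter). The two steps involving the limit are floors: an at least 1.4-fold lower number from compound 1 to compound 2 (0.15 log units; that floor lies within the scatter) and an at least 1.1-fold higher number from compound 2 to compound 3 (0.05 log units; that floor lies within the scatter). As far as these compounds go, none of these three shows a change beyond the scatter, although the true size of the two floor steps remains unknown.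

The expected move is therefore small, in neither direction: no change at the digits printed from compound 3 to compound 4 (within the scatter). For compound 4, the estimated value is 8 mL.min-1.g-1, with an expected range from 5 mL.min-1.g-1 to 15 mL.min-1.g-1.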

Compound 4, intrinsic clearance in microsomes: 16 mL.min-1.g-1
The estimate for compound 4 lay 2.0-fold (0.30 log units) below the measured number; measured number above the stated range.
By their numbers in this assay, from the lowest: compounds 3, 1 and 4 (each within the scatter of the next). At a limit, below all of these: compound 2.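

The earlier compounds shown here differ only in the group on the amine nitrogen, whereas compound 4 alters the chain itself, on a saturated chain carbon bound to an oxygen on an aromatic ring, with (4-hydroxypiperidin-4-yl)methoxy in place of the open propoxy chains. In this assay, this larger change still gives a 2.0-fold higher number from compound 3 to compound 4 (0.30 log units; within the scatter) and a 1.6-fold higher number from compound 1 to compound 4 (0.20 log units; within the scatter), so neither comparison shows a clear difference in removal. The one step beyond the scatter is an at least 2.2-fold higher number from compound 2 to compound 4 (0.35 log units; beyond the scatter), and its true size remains unknown since compound 2 has only a limit, not a number: the limit of < 7 mL.min-1.g-1 in this assay, at which 1 of the 4 values shown sits.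

Compound 4 differs from the others in several features at once, including the ring, the hydroxyl group and the shorter link to the oxygen, so these compounds cannot show which feature, if any, accounts for its number. A piperidin-4-yl group without the hydroxyl, or 4-hydroxypiperidin-4-yl carrying 2-hydroxy-2-methylpropyl or oxan-4-yl on its nitrogen, would each separate one of these features and link this series back to the nitrogen swaps.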